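The compounds below may be only part of what the source reports. "The series", "measured", "known", "first", "only" and "open" are said of these compounds alone.

Measured so far in a functional assay on HeLa cells (Homo sapiens) for inhibition, read by sulforhodamine B assay; on this read-out lower numbers stand for stronger inhibition and higher numbers for weaker inhibition:
compound 1, `CCc1ccc(NC2=CC(=O)c3nc4n(c3C2=O)[C@H]2OC[C@@H](O)[C@H]2OC4)cc1`, gives 3990 nM.
compound 2, `COc1ccc(NC2=CC(=O)c3c(nc4n3[C@H]3OC[C@@H](O)[C@H]3OC4)C2=O)cc1`, gives > 8000 nM, which is a limit of the assay and not a number.
compound 3, `COc1cccc(NC2=CC(=O)c3c(nc4n3[C@H]3OC[C@@H](O)[C@H]3OC4)C2=O)c1`, gives > 8000 nM, again a limit of the assay and not a number.

Compound 1 therefore stands as the only number shown in this assay; the two further values are limits, as both compound 2 and compound 3 sit at the limit of > 8000 nM in this assay, at which 2 of the 3 values shown sit. Among the compounds with values here, the only step between measured compounds that differ in one place is a step that the two limits leave unreadable from compound 2 to compound 3, and its size cannot be read.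

Compound 4, `O=C1C=C(N2CCCC2)C(=O)c2c1nc1n2[C@H]2OC[C@@H](O)[C@H]2OC1`, differs from compound 1 by pyrrolidin-1-yl in place of (4-ethylphenyl)amino on a double-bonded ring carbon. Within the data shown here, no measured step bears on this change: the one step that exists concerns the exchange of a 4-methoxyphenyl for a 3-methoxyphenyl and is unreadable in any case. The expectation for compound 4 thus rests on compound 1 alone, with the weak activity of the series as a whole as the wider background. The expected step of a 1.5-fold higher number from compound 1 to compound 4 (0.18 log units; within the scatter) is therefore small, not clearly beyond the scatter, with a real chance that only a limit is reported, as two of three compounds sit at the limit of > 8000 nM in this assay, at which 2 of the 3 values shown sit. Compound 4 is estimated at 6000 nM, in the range 2000 nM to 20000 nM.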

Compound 4, half-maximal inhibitory concentration: > 16000 nM
Compound 4 ended at the assay's limit; the forecaster's own chance of this, stated with the estimate: 40%; middle value at least 2.6-fold (0.42 log units) away from the limit.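

Within the data shown here, on the double-bonded ring carbon of the shared core, pyrrolidin-1-yl in place of (4-ethylphenyl)amino gives an at least 4.0-fold higher number from compound 1 to compound 4 (0.60 log units; beyond the scatter) in this assay, the first step with a readable lower bound on its size. Compound 4 sits at a limit of the assay and not at a number: the limit of > 16000 nM in this assay, at which 1 of the 4 values shown sits.
The change removes the six-membered aromatic ring of carbon only and the hydrogen-bond donor in a single exchange, so this position is not indifferent to what it carries, and the measurable value of compound 1 does not survive this replacement.

This one step cannot separate the loss of the aromatic ring from the loss of the hydrogen-bond donor, and a cyclopentylamino group, with its amine hydrogen kept and no aromatic ring, would be the kind of group that bears on that question. As far as these compounds go, the step from compound 2 to compound 3 cannot be read, so whether 3-methoxyphenyl and 4-methoxyphenyl differ on the amine nitrogen also stays open, as does how far the true value of compound 4 lies beyond its limit.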